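Swapping 4-hydroxy-2-methylphenyl for 4-ethylphenyl

A few compounds are considered here, and "the series" means these few. Any claim that something is new, unique, unknown or untested is made for them only; others in the source may bear on it.

Among the compounds with values here, in a functional assay on SK-MEL-28 cells (Homo sapiens) for inhibition, read by sulforhodamine B assay, with a stated time of 48 h (a higher number here means a weaker inhibitor of growth, a lower number a stronger inhibitor of growth), compound 2 `Cc1cc(O)ccc1C1=NN(c2ccc(S(C)(=O)=O)cc2)C(=O)CC1` gives 9560 nM, the highest of the two numbers measured so far, whereas compound 1 `Cc1ccc(C2=NN(c3ccc(S(C)(=O)=O)cc3)C(=O)CC2)cc1` gives 660 nM. Within the data shown here, the one measured step, a 14-fold higher number from compound 1 to compound 2 (1.16 log units; beyond the scatter), is large and lies beyond the scatter; it put 4-hydroxy-2-methylphenyl in place of 4-methylphenyl. Compound 3 `CCc1ccc(C2=NN(c3ccc(S(C)(=O)=O)cc3)C(=O)CC2)cc1` changes the same place: 4-ethylphenyl in place of 4-hydroxy-2-methylphenyl on a carbon with a double bond to nitrogen, with 4-ethylphenyl in place of 4-hydroxy-2-methylphenyl on a carbon with a double bond to nitrogen. The entering group resembles the 4-methylphenyl of compound 1, so the large 14-fold higher number from compound 1 to compound 2 (1.16 log units; beyond the scatter) is expected to be mostly reversed in this assay, towards a lower number. Among the measured compounds shown here, no measured compound carries 4-ethylphenyl, so this rests on a single step. The expected change is a 12-fold lower number from compound 2 to compound 3 (1.08 log units; beyond the scatter). For compound 3 the estimate is 800 nM, with an expected range of 300 nM to 2200 nM.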

Compound 3, concentration for 50% growth inhibition: 1840 nM
Compound 3: the middle estimate sits 2.3-fold (0.36 log units) below what was measured; low and high end bracket the measured number.
By their numbers in this assay, from the lowest: compound 1; then compound 3; then compound 2.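

Putting 4-ethylphenyl in place of 4-hydroxy-2-methylphenyl gave a 5.2-fold lower number from compound 2 to compound 3 (0.72 log units; beyond the scatter) in this assay, so this position can recover much of the loss seen with compound 2 when the entering group carries no hydrogen-bond donor or acceptor. The recovery is only partial, and the position also distinguishes between two close alkylphenyl groups: adding one methyl to the chain gave a 2.8-fold higher number from compound 1 to compound 3 (0.45 log units; beyond the scatter). Compound 1 therefore keeps the lowest number of the three, and the longer chain of compound 3 brought no gain over the methyl. No measurement here explains these differences. The compounds shown leave open whether the hydroxyl or the extra methyl of compound 2 accounts for its high number, and whether a 4-methoxyphenyl or 4-propylphenyl group would follow the same trend.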